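Series notes: ethoxy for butyl on the aromatic carbon

This account rests on a few compounds, and the source may have more. Where it says the series, first, only, none or still open, it means among the compounds named here.

In an ADME assay on MDCK cells (Canis lupus familiaris) for cytotoxicity, read by microscopy, with a stated time of 48 h (a higher number here means that more compound is tolerated, a lower number that less compound is tolerated), compound 3 `CCCCc1ccsc1CN[C@@H]1C[C@H]2C[C@@H]([C@H]1C)C2(C)C` gives 25000 nM. Among the three measured numbers it stands second highest: compound 1 `CCCc1ccsc1CN[C@@H]1C[C@H]2C[C@@H]([C@H]1C)C2(C)C` gives 50000 nM, and a 2.0-fold lower number from compound 1 to compound 3 (0.30 log units; within the scatter) is within the scatter, while compound 2 `C[C@H]1[C@H](NCc2sccc2C2CCCCC2)C[C@H]2C[C@@H]1C2(C)C` gives 1560 nM, and a 16-fold higher number from compound 2 to compound 3 (1.20 log units; beyond the scatter) is well beyond it.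

Compound 4 `CCOc1ccsc1CN[C@@H]1C[C@H]2C[C@@H]([C@H]1C)C2(C)C` differs from compound 3 in one place: ethoxy in place of butyl on an aromatic carbon. Among the measured compounds shown here, two measured steps touch the same aromatic carbon and both are large: a 32-fold lower number from compound 1 to compound 2 (1.51 log units; beyond the scatter) and a 16-fold higher number from compound 2 to compound 3 (1.20 log units; beyond the scatter). They show that the group at this place can move the readout in this assay far, whereas a 2.0-fold lower number from compound 1 to compound 3 (0.30 log units; within the scatter) shows that a modest change in chain length stays within the scatter. For the measured compounds named here, no measured compound carries an oxygen at this place, so the direction of an ethoxy step is not settled by the data. Since the change runs from butyl to a shorter, non-ring group, the expected step is small, a 1.6-fold higher number from compound 3 to compound 4 (0.20 log units; within the scatter), as an estimate. Compound 4 is therefore expected at 40000 nM, with a range from 15000 nM to 100000 nM.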

Compound 4, minimum cytotoxic concentration: 50000 nM
Estimate against measurement, compound 4: 1.3-fold (0.10 log units) below; the range from low to high includes it.
By their numbers in this assay, from the lowest: compound 2; then compounds 3, 1 and 4 (each within the scatter of the next).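

In this assay, ethoxy brings an oxygen to this aromatic carbon and the number stays with those of the open-chain groups, with a 2.0-fold higher number from compound 3 to compound 4 (0.30 log units; within the scatter) against butyl and no change at the digits printed from compound 1 to compound 4 (within the scatter) against propyl. Against cyclohexyl, a 32-fold higher number from compound 2 to compound 4 (1.51 log units; beyond the scatter) is large, so among these four compounds only compound 2 stands apart, and an oxygen at this place does not by itself take the number out of the range of the open-chain compounds. No supporting data bear on why the numbers fall this way.

On these data alone, whether the low number of compound 2 belongs to cyclohexyl alone or to ring groups at this carbon more widely stays open, and a cyclopropyl or phenyl group would speak to that. Also open, as far as these compounds go, is how this place responds to a longer chain such as hexyl, or to an amine or a carboxylic acid.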